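Moving the thiazole attachment point on the shared core

The source may hold more compounds than are shown below. What is called first, only, known or untested is meant among the compounds shown, and "the series" means these compounds.

Measured so far in an ADME assay on microsomes from liver (Homo sapiens) for metabolic stability, read by HPLC, with a stated time of 60 min, tested at 0.2 mg/mL; a lower number here means that the compound disappears faster, a higher number that the compound lasts longer
Compound 1 `O=C(NCc1ccc(Cl)cc1Cl)[C@@H]1CCC(=O)N1c1ccsc1` gives 0.0417 h
Compound 2 `O=C(NCc1ccc(Cl)cc1Cl)[C@@H]1CCC(=O)N1c1ccco1` gives 0.0867 h
Compound 3 `O=C(NCc1ccc(Cl)cc1Cl)[C@@H]1CCC(=O)N1c1nccs1` gives 0.125 h

Compound 3, at 0.125 h, lies within the scatter of compound 2, a 1.4-fold higher number from compound 2 to compound 3 (0.16 log units; within the scatter). It stands clear of compound 1, a 3.0-fold higher number from compound 1 to compound 3 (0.48 log units; beyond the scatter).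

Compound 4 `O=C(NCc1ccc(Cl)cc1Cl)[C@@H]1CCC(=O)N1c1cscn1` has the same atoms as compound 3, joined differently: 1,3-thiazol-4-yl in place of 1,3-thiazol-2-yl on an amide-type nitrogen in a ring. Among the compounds with values here, no measured step shifts the attachment point within one group, so the nearest guides are the exchanges of one whole group for another at this place. Those steps were modest: besides the two above, there is a 2.1-fold higher number from compound 1 to compound 2 (0.32 log units; beyond the scatter). Within the data shown here, compound 1, at 0.0417 h, has the lowest number so far, and it shows how far such an exchange has moved the value. A change of attachment point is therefore expected to produce a step of no more than that modest size, and probably none beyond the scatter. The estimated step is a 1.4-fold lower number from compound 3 to compound 4 (0.14 log units; within the scatter). In this assay the estimate for compound 4 is 0.09 h, with an expected range of 0.045 h to 0.18 h.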

Compound 4, half-life: 0.08 h
Beside the measured number, compound 4's estimate is 1.1-fold (0.05 log units) above it, within the range that was stated.
By their numbers in this assay, from the lowest: compounds 1, 4, 2 and 3 (each within the scatter of the next, the first and the last beyond it).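

Among the compounds shown, this is the only shift of attachment point within one group at the amide-type nitrogen, and in this assay it gives a 1.6-fold lower number from compound 3 to compound 4 (0.19 log units; within the scatter), so the two thiazole isomers cannot be told apart here. Compound 4 also cannot be told apart from the furan-2-yl compound, with a 1.1-fold lower number from compound 2 to compound 4 (0.03 log units; within the scatter). The comparison with the thiophen-3-yl compound gives a 1.9-fold higher number from compound 1 to compound 4 (0.28 log units; within the scatter), so compound 4, unlike compounds 2 and 3, does not stand clear of compound 1. The data shown offer no measurement that would explain these steps.

On these data alone, it remains open whether a six-membered ring such as pyridin-2-yl, or a methyl group on the thiazole, would give a half-life clear of these four compounds. As far as these compounds go, all four also keep the same dichlorobenzyl amide, so it is unknown whether these steps would hold with another group there.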